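Swapping the pyrazole for a methylated imidazole

This account rests on a few compounds, and the source may have more. Where it says the series, first, only, none or still open, it means among the compounds named here.

Measured so far:
- compound 1, `CC(C)Oc1ccc(-c2nnc(-c3ccnn3C)s2)cc1Cl`: 7.04
- compound 2, `CC(C)Oc1ccc(-c2nnc(-c3ccccc3)s2)cc1Cl`: 8.65
- compound 3, `CC(C)Oc1ccc(-c2nnc(-c3cn[nH]c3)s2)cc1Cl`: 5

In a physicochemical assay for lipophilicity, at pH 7.4 (a lower number here means a more polar compound, a higher number a more lipophilic compound), compound 3 stands lowest of the three, with compound 1 nearest and compound 2 furthest. The step to compound 4, `CC(C)Oc1ccc(-c2nnc(-c3cncn3C)s2)cc1Cl`, is 1-methyl-1H-imidazol-5-yl in place of 1H-pyrazol-4-yl on an aromatic carbon. Going by the values given here, two measured steps bear on it. The change from compound 2 to compound 3 gave a number 3.65 log units lower from compound 2 to compound 3 (beyond the scatter), and the change from compound 1 to compound 3 gave a number 2.04 log units lower from compound 1 to compound 3 (beyond the scatter). Among the compounds with values here, compound 4, like compound 1, carries a methyl group on its five-membered ring and has 0 hydrogen-bond donors, so the move from compound 3 to compound 4 is expected to run in the opposite direction to the step from compound 1 to compound 3, though no measured compound shows this exact ring. Compound 4 is therefore expected to give 6.5 in this assay, between 5.5 and 7.5, an expected rise of a number 1.50 log units higher from compound 3 to compound 4 (beyond the scatter).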

Compound 4, distribution coefficient: 5.7
Beside the measured number, compound 4's estimate is 0.80 log units above it, within the range that was stated.
By their numbers in this assay, from the lowest: compound 3; then compound 4; then compound 1; then compound 2.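

In this assay, the two methylated five-membered rings do not behave alike at this position, since moving from the 1-methyl-1H-pyrazol-5-yl ring to the 1-methyl-1H-imidazol-5-yl ring gives a number 1.34 log units lower from compound 1 to compound 4 (beyond the scatter) even though both rings have 0 hydrogen-bond donors. A methylated ring without a donor is therefore not enough to bring a compound close to compound 1, as the step from the 1H-pyrazol-4-yl ring shows only a number 0.70 log units higher from compound 3 to compound 4 (beyond the scatter) and stays well short of that level. Compared with phenyl, the 1-methyl-1H-imidazol-5-yl ring gives a number 2.95 log units lower from compound 2 to compound 4 (beyond the scatter) and so sits much nearer the polar end of this series.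

Nothing available here explains why the two methylated rings differ. Going by these compounds, how a pyridine ring or a ring bearing a carboxylic acid would read at this position also remains open.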